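A few compounds are considered here, and "the series" means these few. Any claim that something is new, unique, unknown or untested is made for them only; others in the source may bear on it.

In a functional assay on the whole organism with Rattus norvegicus as the target (a lower number here means that less compound is needed, a higher number that more compound is needed for the effect), compound 3 (`CCOC(=O)C(=O)Nc1cccc(N2CCCCC2)c1C#N`) gives 2.2 mg/kg, second highest of the three values, with compound 1 (`CCOC(=O)C(=O)Nc1cccc(N(C)C)c1C#N`) at 0.2 mg/kg and compound 2 (`CCOC(=O)C(=O)Nc1cccc(OC)c1C#N`) at 5.3 mg/kg. The next change leads to compound 4 (`CCOC(=O)C(=O)Nc1cccc(C(=O)OC)c1C#N`): methoxycarbonyl in place of piperidin-1-yl on an aromatic carbon, ortho to a cyano group. Replacement at this carbon has already shifted this assay: an 11-fold higher number from compound 1 to compound 3 (1.04 log units; beyond the scatter) and a 27-fold higher number from compound 1 to compound 2 (1.42 log units; beyond the scatter) were both large, while a 2.4-fold lower number from compound 2 to compound 3 (0.38 log units; beyond the scatter) was modest. Going by the values given here, no measured compound carries methoxycarbonyl, so the direction is uncertain, but a small upward move is expected, given the value of compound 2 at 5.3 mg/kg. The estimated step is a 1.6-fold higher number from compound 3 to compound 4 (0.20 log units; within the scatter). Compound 4 is expected at 3.5 mg/kg, within an estimated range of 0.8 mg/kg to 15 mg/kg.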

Compound 4, dose for half-maximal effect: 1.2 mg/kg
For compound 4 the middle estimate is 2.9-fold (0.46 log units) above the measured one; low and high end bracket the measured number.
By their numbers in this assay, from the lowest: compound 1; then compounds 4 and 3 (each within the scatter of the next); then compound 2.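

In this assay, methoxycarbonyl and piperidin-1-yl cannot be told apart at this carbon (a 1.8-fold lower number from compound 3 to compound 4 (0.26 log units; within the scatter)), although they share neither a ring nor a count of heavy atoms. Methoxycarbonyl does separate from methoxy (a 4.4-fold lower number from compound 2 to compound 4 (0.65 log units; beyond the scatter)), so the two oxygen-bearing groups do not behave alike here, while compound 1 with dimethylamino keeps the lowest number (a 6.0-fold higher number from compound 1 to compound 4 (0.78 log units; beyond the scatter)). Nothing available explains these differences. Going by these compounds, whether a carboxylic acid, a primary amine or pyrrolidin-1-yl at this carbon would approach the number of compound 1 remains open.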